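Notes on a stereocentre change at compound 2

The source may hold more compounds than are shown below. What is called first, only, known or untested is meant among the compounds shown, and "the series" means these compounds.

Measured in a functional assay on CCRF-CEM cells (Homo sapiens) for cytotoxicity; a higher number here means a weaker inhibitor, a lower number a stronger inhibitor:
- compound 1 `Cc1cn([C@@H]2CC(F)(F)[C@H](CO)O2)c(=O)nc1O`: > 100000 nM (a limit, not a number)
- compound 2 `Nc1nc(O)c2ncn([C@@H]3C=C(F)[C@H](CO)O3)c2n1`: 58400 nM

Among the measured compounds shown here, compound 2 holds the only numeric reading so far, 58400 nM. The other reading is a limit, so no ranking follows from the two entries.

The next compound is compound 3 `Nc1nc(O)c2ncn([C@H]3C=C(F)[C@H](CO)O3)c2n1`. Its relation to compound 2 is as follows: the two compounds have the same atoms and bonds and differ only in configuration as drawn: 1 of 2 stereo elements differ; a stereocentre at a saturated ring carbon is drawn S in compound 2 and R in compound 3. For the measured compounds named here, no measured step shows what such a change does here. The estimated 1.4-fold higher number from compound 2 to compound 3 (0.14 log units; within the scatter) is small, with nothing expected beyond the scatter in this assay, or at most a slight weakening. For compound 3 the estimated value is 80000 nM, with an expected range of 30000 nM to 100000 nM.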

Compound 3, half-maximal inhibitory concentration: > 100000 nM
Compound 3 was reported as a limit; the forecaster's own chance of this, stated with the estimate: 50%; middle value at least 1.2-fold (0.09 log units) from the limit.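

In this assay, the change at this saturated ring carbon from S to R gives an at least 1.7-fold higher number from compound 2 to compound 3 (0.23 log units; that floor lies within the scatter). Among the compounds shown here, this is the first step to isolate configuration, and it shows no gain from the R form, although it gives only a floor and not a size: the limit of > 100000 nM in this assay, at which 2 of the 3 values shown sit. For the compounds shown here, it is also the only comparison here with nothing else altered: the fact that compounds 2 and 3 differ only in the configuration as drawn.

Going by these compounds, whether the true step lies beyond the scatter stays open. Also open, on these data alone, is how a carboxylic acid or a longer chain on the shared core would read with either configuration.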